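The source may hold more compounds than are shown below. What is called first, only, known or untested is meant among the compounds shown, and "the series" means these compounds.

Measured so far:
- compound 1 `O=c1n(Cc2nc(-c3nccs3)cn2CCCCO)c2cnccc2n1C1CC1`: < 8 mL.min-1.g-1
- compound 2 `CC(C)n1nc(Cn2nc3ccccc3c2OCCCO)c2ccccc21`: 246 mL.min-1.g-1
- compound 3 `CC(C)n1nc(Cn2nc3c(c2CCCCO)CCCC3)c2ccccc21`: > 320 mL.min-1.g-1

In an ADME assay on microsomes from liver (Homo sapiens) for metabolic stability (a lower number here means slower removal, a higher number faster removal of the compound), compound 1 gives < 8 mL.min-1.g-1, which is a limit of the assay rather than a number. Compound 1 therefore sits at the limit of < 8 mL.min-1.g-1 in this assay, at which 1 of the 3 values shown sits, the slow end of what this assay can report. In this assay compound 2 gives 246 mL.min-1.g-1. Compound 3 gives > 320 mL.min-1.g-1, again a limit of the assay, and it sits at the limit of > 320 mL.min-1.g-1 in this assay, at which 1 of the 3 values shown sits. Going by the values given here, compound 2 and compound 3 are built on a different core from compound 1, so the three values show only that compound 1 is the one cleared slowest among them.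

Compound 4 `Cn1nccc1-c1cn(CCCCO)c(Cn2c(=O)n(C3CC3)c3ccncc32)n1` keeps the core of compound 1 and differs in one place: 1-methyl-1H-pyrazol-5-yl in place of 1,3-thiazol-2-yl on an aromatic carbon. Among the compounds with values here, no measured pair shows what this swap does in this assay. The expectation is a step of a number no lower from compound 1 to compound 4 (the limit leaves the size open), within the usual scatter. Compound 4 is expected to give about 8 mL.min-1.g-1, between 4 mL.min-1.g-1 and 25 mL.min-1.g-1.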

Compound 4, intrinsic clearance in microsomes: < 8 mL.min-1.g-1
Compound 4: a limit, no number; the forecaster's own chance of this, stated with the estimate: 55%; the middle value sits exactly at the limit.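

In this assay, going by these compounds alone, compound 4 gives < 8 mL.min-1.g-1, a limit of the assay, and compound 1 stands at the same limit, so no step between the two can be read. Still open, as far as these compounds go, is whether 1-methyl-1H-pyrazol-5-yl in place of 1,3-thiazol-2-yl changes the clearance at all.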